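Replacing an aryl hydrazide by a diacyl hydrazide

The source may hold more compounds than are shown below. What is called first, only, known or untested is meant among the compounds shown, and "the series" means these compounds.

In a functional assay on MDA-MB-231 cells (Homo sapiens) for antiproliferative activity, read by MTT assay, with a stated time of 24 h (a higher number here means a weaker inhibitor, a lower number a stronger inhibitor), compound 1 `O=C(NNc1ccccc1Cl)c1cccc(NS(=O)(=O)c2cnc(O)nc2O)c1` gives 2090 nM. Compound 2 `O=C(NNc1ccccc1Cl)c1ccccc1NS(=O)(=O)c1cnc(O)nc1O` gives 18900 nM in this assay, the highest of the two numbers, and its gap to compound 1 lies beyond the scatter. Compound 3 `O=C(NNC(=O)c1ccccc1NS(=O)(=O)c1cnc(O)nc1O)c1ccccc1F` has not been measured; it differs from compound 2 by (2-fluorophenyl)carbonyl in place of 2-chlorophenyl on an amine nitrogen. Within the data shown here, no measured pair shows this change, so the step is expected to be modest, with no clear direction, as a 1.6-fold lower number from compound 2 to compound 3 (0.20 log units; within the scatter). Compound 3 is estimated at 12000 nM in this assay, within a range from 3000 nM to 45000 nM.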

Compound 3, half-maximal inhibitory concentration: > 20000 nM
Compound 3: no number, only a limit; the forecaster's own chance of this, stated with the estimate: 10%; at least 1.6-fold (0.22 log units) between middle value and limit.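

In this assay compound 3 gives > 20000 nM, which is a limit of the assay and not a number. Placing (2-fluorophenyl)carbonyl in place of 2-chlorophenyl on this amine nitrogen gives an at least 1.0-fold higher number from compound 2 to compound 3 (0.02 log units; that floor lies within the scatter), so this change brings no lower number. How much higher the true value lies stays unread: the limit of > 20000 nM in this assay, at which 1 of the 3 values shown sits.

The carbonyl and the fluorine enter together, and the compounds shown do not separate them, as a (2-chlorophenyl)carbonyl group on the same nitrogen could. Also open, as far as these compounds go, is how an acetyl group would read here, and how this change would read on the core of compound 1.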